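The compounds below may be only part of what the source reports. "The series", "measured", "known", "first", "only" and "open" are said of these compounds alone.

Working notes on the series. Going by the values given here, compound 1 `CC[C@](O)(c1cn(Cc2ccc3c(-c4ccc(F)cc4)c(C(N)=O)sc3c2)nn1)C(F)(F)F` carries a carbamoyl group on the shared core and, in an assay on blood for inhibition of Polyunsaturated fatty acid 5-lipoxygenase (Homo sapiens) (a higher number here means a weaker inhibitor, a lower number a stronger inhibitor), compound 1 gives 21 nM, the lowest of the three numbers measured so far. Compound 2 `CCC(O)(c1cn(Cc2ccc3c(-c4ccccc4)c(CO)sc3c2)nn1)C(F)(F)F` gives 64 nM and compound 3 `CC[C@@](O)(c1cn(Cc2ccc3c(-c4ccc(F)cc4)c(C(N)=O)sc3c2)nn1)C(F)(F)F` gives 154 nM. Among the compounds with values here, the only single-change step on record is a 7.3-fold higher number from compound 1 to compound 3 (0.87 log units; beyond the scatter); it rests on the fact that compounds 1 and 3 differ only in the configuration as drawn and says nothing about the substituent on the carbonyl carbon. Compound 2 differs from compound 1 in more than one place, so its value can only be set beside that of compound 1 without attributing the gap.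

Compound 4 `CC[C@](O)(c1cn(Cc2ccc3c(-c4ccc(F)cc4)c(C(=O)O)sc3c2)nn1)C(F)(F)F` is the next step: hydroxy in place of amino on a carbonyl carbon. Within the data shown here, no measured step touches the carbonyl substituent, so there is no precedent for the size or direction of this change. The expectation for compound 4 in this assay is therefore a step of about a 2.9-fold higher number from compound 1 to compound 4 (0.46 log units; beyond the scatter) from compound 1, with wide uncertainty. The estimate for compound 4 is 60 nM, within a range of 10 nM to 400 nM.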

Compound 4, half-maximal inhibitory concentration: > 20000 nM
Compound 4: a limit, no number; the forecaster's own chance of this, stated with the estimate: 5%; middle value at least 330-fold (2.52 log units) away from the limit.
By their numbers in this assay, from the lowest: compound 1; then compound 2; then compound 3. At a limit, above all of these: compound 4.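

In this assay compound 4 stands at a limit of the assay, not a number: > 20000 nM. Hydroxy in place of amino on a carbonyl carbon gives an at least 950-fold higher number from compound 1 to compound 4 (2.97 log units; beyond the scatter), the first reading for this position, and it shows that the series is far from indifferent to the substituent there. This step exceeds the only earlier single-change step, a 7.3-fold higher number from compound 1 to compound 3 (0.87 log units; beyond the scatter), so on the compounds shown, the change of carbamoyl to carboxy counts for more than the configuration as drawn.

Going by these compounds, whether a methyl ester or a methyl amide on the same carbonyl carbon would stay with compound 1 or fall with compound 4 remains open. The limit also leaves the true size of the step open.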